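Swapping a methoxyphenyl for a methylphenyl on a shared core

This account rests on a few compounds, and the source may have more. Where it says the series, first, only, none or still open, it means among the compounds named here.

Measured compounds:
compound 1 `COc1cc(-c2ccnc3cc(-c4ccc5cc[nH]c5c4)nn23)cc(OC)c1OC` — 187 nM
compound 2 `COc1ccc(-c2cc3nccc(-c4cc(OC)c(OC)c(OC)c4)n3n2)cc1F` — 2840 nM
compound 3 `COc1ccc(-c2cc3nccc(-c4cc(OC)c(OC)c(OC)c4)n3n2)cc1` — 404 nM

All three values come from a functional assay on HCT-116 cells (Homo sapiens) for inhibition, read by CCK-8 assay, with a stated time of 48 h; a higher number here means a weaker inhibitor, a lower number a stronger inhibitor. Compound 3 sits second highest of the three numbers: compound 1 is its nearest neighbour, with a 2.2-fold higher number from compound 1 to compound 3 (0.33 log units; beyond the scatter) separating them, while compound 2 is furthest, as shown by a 7.0-fold lower number from compound 2 to compound 3 (0.85 log units; beyond the scatter). Compound 3 therefore lies between a stronger and a clearly weaker inhibitor.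

Compound 4 `COc1cc(-c2ccnc3cc(-c4cccc(C)c4)nn23)cc(OC)c1OC` has not yet been tested in this assay. It differs from compound 3 in one place: 3-methylphenyl in place of 4-methoxyphenyl on an aromatic carbon. The group sits on an aromatic carbon of the five-membered ring of the shared core, next to the ring nitrogen.

Neither measured step matches this change directly. The step of a 2.2-fold higher number from compound 1 to compound 3 (0.33 log units; beyond the scatter) shows that replacing the ring group at this position can move the number modestly, and a 7.0-fold lower number from compound 2 to compound 3 (0.85 log units; beyond the scatter) shows that a single small substituent on that ring can shift it more strongly. A small, uncertain shift is therefore expected for compound 4, with a step of a 1.5-fold higher number from compound 3 to compound 4 (0.17 log units; within the scatter) relative to compound 3. Compound 4 is estimated at 600 nM, with a likely range from 200 nM to 2000 nM.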

Compound 4, half-maximal inhibitory concentration: 6150 nM
Beside the measured number, compound 4's estimate is 10-fold (1.01 log units) below it; measured number outside the range, above it.
By their numbers in this assay, from the lowest: compound 1; then compound 3; then compound 2; then compound 4.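

In this assay, the choice of phenyl group on this aromatic carbon of the five-membered ring can matter far more than compound 3 alone suggested: 3-methylphenyl in place of 4-methoxyphenyl gives a 15-fold higher number from compound 3 to compound 4 (1.18 log units; beyond the scatter). The fluoro compound had been the weakest of the series, yet its 3-fluoro-4-methoxyphenyl group still does better than 3-methylphenyl, as shown by a 2.2-fold higher number from compound 2 to compound 4 (0.34 log units; beyond the scatter), and the 1H-indol-6-yl group does far better, with a 33-fold higher number from compound 1 to compound 4 (1.52 log units; beyond the scatter). This makes compound 4 the weakest of the four, and it shows that a group with no oxygen and only a small methyl on its phenyl ring is not a neutral replacement here, even though it is close in size to the group it replaces.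

This single step changes both the kind of substituent and its numbered place on the phenyl ring, so the compounds shown leave open which of the two matters, a question that 4-methylphenyl and 3-methoxyphenyl groups at this position would address. Nothing available explains why the number rises so sharply.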